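Oxidised six-membered ring in place of the dihydroxyphenyl

The source may hold more compounds than are shown below. What is called first, only, known or untested is meant among the compounds shown, and "the series" means these compounds.

Compound 2 `CC(=O)NS(=O)(=O)c1ccc(-n2nc(-c3ccccc3)cc2-c2cc(O)ccc2O)cc1` carries a 2,5-dihydroxyphenyl on the shared core. Within the data shown here, in a functional assay on cells (Cancer cell lines, Homo sapiens) for cytotoxicity, read by sulforhodamine B assay, with a stated time of 48 h (on this read-out lower numbers stand for stronger inhibition of growth and higher numbers for weaker inhibition of growth), compound 2 gives 100000 nM, the highest of the two numbers measured so far; its nearest neighbour, compound 1 `COc1ccc(OC)c(-c2cc(-c3ccccc3)nn2-c2ccc(S(=O)(=O)NC(C)=O)cc2)c1`, gives 13300 nM, and the step of a 7.5-fold higher number from compound 1 to compound 2 (0.88 log units; beyond the scatter) lies beyond the scatter.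

Compound 3 `CC(=O)NS(=O)(=O)c1ccc(-n2nc(-c3ccccc3)cc2C2=CC(=O)C=CC2=O)cc1` is not yet measured. It differs from compound 2 by a group of 8 heavy atoms (6 carbon, 2 oxygen; one six-membered non-aromatic ring of carbon only) in place of a group of 8 heavy atoms (6 carbon, 2 oxygen; one six-membered aromatic ring of carbon only), on an aromatic carbon. The change removes both hydrogen-bond donors of the dihydroxyphenyl and turns the aromatic ring into a non-aromatic one with four double bonds outside aromatic rings.

Among the measured compounds shown here, no measured step covers this change. For the measured compounds named here, the only step available, from the dimethoxy to the dihydroxy variant, moved the number by a 7.5-fold higher number from compound 1 to compound 2 (0.88 log units; beyond the scatter) and concerns a different alteration of the same ring, so it gives no direct guide. Since compound 2 already stands at the top of the range, a further increase is less likely than a decrease; a step of the order of a 3.3-fold lower number from compound 2 to compound 3 (0.52 log units; beyond the scatter) is expected, with wide uncertainty. For compound 3 the estimate in this assay is 30000 nM, with a range from 5000 nM to 100000 nM.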

Compound 3, concentration for 50% growth inhibition: 100000 nM
Compound 3: the middle estimate sits 3.3-fold (0.52 log units) below what was measured; the measured number falls inside the stated range.
By their numbers in this assay, from the lowest: compound 1; then compounds 2 and 3 (each within the scatter of the next).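

In this assay, replacing the 2,5-dihydroxyphenyl with the non-aromatic six-membered ring gives no change at the digits printed from compound 2 to compound 3 (within the scatter). At this position, on an aromatic carbon of a five-membered aromatic ring with 2 nitrogen, the number therefore stays the same although both hydrogen-bond donors and the aromatic ring are gone. Among these compounds, the 2,5-dimethoxyphenyl of compound 1 is now the only one of the three groups that stands apart beyond the scatter, with a 7.5-fold higher number from compound 1 to compound 3 (0.88 log units; beyond the scatter) matching the step already seen to the dihydroxy variant; nothing available accounts for this pattern.

Three groups at one position give little to build on, and the compounds shown leave open whether the lower number of compound 1 belongs to the methoxy groups themselves or would also appear with other groups on the phenyl ring here, such as a single methoxy, an amine or a carboxylic acid. They also leave open whether the same order of the three groups would hold if the phenyl group on the shared core were replaced.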